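The source may report more compounds than this note shows. Statements on the series, on what has been measured and on what is new or still open speak of the compounds shown alone.

Measured compounds:
compound 1, `COc1cccc(OC)c1OCCNC[C@H]1Oc2ccccc2O[C@H]1C`: 3.16 nM
compound 2, `COc1cccc(OC)c1OCCNC[C@H]1Oc2ccccc2O[C@@H]1C`: 11.5 nM

In a functional assay for antagonist activity at Adrenergic receptor alpha-1 (Rattus norvegicus) (a higher number here means weaker binding, a lower number tighter binding), compound 1 gives 3.16 nM, the lower of the two numbers. Compound 2 lies nearest, and the step of a 3.6-fold higher number from compound 1 to compound 2 (0.56 log units; beyond the scatter) shows that the shared core responds noticeably even when only the configuration at one saturated ring carbon changes, a point resting on (the fact that compounds 1 and 2 differ only in the configuration as drawn).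

Compound 3, `COc1cccc(OC)c1OCCNC[C@H]1Oc2ccccc2O[C@H]1c1ccc(Cl)cc1`, is not yet measured in this assay. It differs from compound 1 by 4-chlorophenyl in place of methyl on a saturated ring carbon. Within the data shown here, no measured step speaks to this kind of exchange: the only step available, from compound 1 to compound 2, alters configuration and not the identity of the group on that carbon. A replacement of a small group by a much larger aromatic one at the same carbon is expected to shift the number, and a rise is judged more likely than a fall, though with wide uncertainty. For compound 3 the estimate is 8 nM, within 1.5 nM to 50 nM, a step of a 2.5-fold higher number from compound 1 to compound 3 (0.40 log units; beyond the scatter) expected in this assay.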

Compound 3, dissociation constant: 81.3 nM
Compound 3: the middle estimate sits 10-fold (1.01 log units) below what was measured, and the stated range ends below it.
By their numbers in this assay, from the lowest: compound 1; then compound 2; then compound 3.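

In this assay, putting 4-chlorophenyl in place of methyl on this saturated ring carbon gives a 26-fold higher number from compound 1 to compound 3 (1.41 log units; beyond the scatter), a larger move than the change of configuration alone, a 3.6-fold higher number from compound 1 to compound 2 (0.56 log units; beyond the scatter). Among these compounds, then, the number depends more on which group this carbon carries than on how its methyl is drawn, although binding is weakened rather than lost, with compound 3 at 81.3 nM. Nothing in hand explains why this exchange raises the number.

The compounds shown do not separate the contribution of the aromatic ring from that of the chlorine, and an unsubstituted phenyl would speak to that, while an ethyl would show how the number moves with a small step up from methyl. As far as these compounds go, how 4-chlorophenyl behaves in the opposite configuration at this carbon also remains open.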